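Removing the methyl from the amine: compound 3 to compound 4

The compounds below may be only part of what the source reports. "The series", "measured", "known", "first", "only" and "open" are said of these compounds alone.

Measured compounds:
- compound 1, `COc1ccc(CNCCCNS(=O)(=O)c2cc(C(F)(F)F)cc(C(F)(F)F)c2)cc1OC`, 3800 nM
- compound 2, `O=S(=O)(NCCCNCc1ccc(Cl)c(C(F)(F)F)c1)c1cc(C(F)(F)F)cc(C(F)(F)F)c1`, 5900 nM
- compound 3, `CN(CCCNS(=O)(=O)c1cc(C(F)(F)F)cc(C(F)(F)F)c1)Cc1ccccc1`, 28000 nM

All three share the same core, a sulfonamide linked by a short saturated chain to an amine bearing a benzyl-type group. In a functional assay on A2780 cells (Homo sapiens) for inhibition, read by MTT assay, with a stated time of 72 h (a higher number here means a weaker inhibitor of growth, a lower number a stronger inhibitor of growth), compound 3 gives the highest of the three numbers; compound 2 sits well below it and compound 1 lower still, both gaps beyond the scatter.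

Compound 4 is `COc1ccc(CNCCCNS(=O)(=O)c2cc(C(F)(F)F)cc(C(F)(F)F)c2)cc1`. Against compound 3 the change is (4-methoxybenzyl)amino in place of benzyl(methyl)amino on a saturated chain carbon, three bonds along the chain from a sulfonamide nitrogen. Among the measured compounds shown here, no measured step covers exactly this change. For the measured compounds named here, the only step available, a 1.6-fold higher number from compound 1 to compound 2 (0.19 log units; within the scatter), swaps one aryl pattern for another while keeping the secondary amine, and it stays within the scatter. Compound 4 keeps that secondary amine and carries a methoxy-bearing ring, which places it nearer compound 1 and compound 2 than compound 3 in structure. Compound 4 is therefore expected to land near those two, a step of a 5.6-fold lower number from compound 3 to compound 4 (0.75 log units; beyond the scatter). The estimate for compound 4 is 5000 nM, with a range from 2000 nM to 15000 nM.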

Compound 4, concentration for 50% growth inhibition: 1700 nM
For compound 4 the middle estimate is 2.9-fold (0.47 log units) above the measured one, outside the stated range (below it).
By their numbers in this assay, from the lowest: compound 4; then compounds 1 and 2 (each within the scatter of the next); then compound 3.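

Read in this assay the change on a saturated chain carbon, three bonds along the chain from a sulfonamide nitrogen, gives the largest step so far (a 16-fold lower number from compound 3 to compound 4 (1.22 log units; beyond the scatter)). The ring pattern also proves to matter while the secondary amine stays: the earlier swap of aryl patterns stayed within the scatter, yet both new steps among secondary amines lie beyond it (a 3.5-fold lower number from compound 2 to compound 4 (0.54 log units; beyond the scatter); a 2.2-fold lower number from compound 1 to compound 4 (0.35 log units; beyond the scatter)), leaving compound 4 with the lowest number of the four. No measurement here explains these differences.

Going by these compounds, the large step combines loss of the amine methyl with gain of the methoxy, so their separate shares stay unknown. On these data alone, a secondary amine carrying plain benzyl, or the 4-methoxybenzyl group on a methylated amine, would separate them, and a longer chain remains open too.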